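A few compounds are considered here, and "the series" means these few. Any claim that something is new, unique, unknown or untested is made for them only; others in the source may bear on it.

In a functional assay on the whole organism for inhibition, with Mus musculus as the target (a lower number here means that less compound is needed, a higher number that more compound is needed for the effect), compound 1 `CCCCNC(=O)Nc1cccc2c1CN(C)CC2c1ccccc1` gives about 40 mg/kg and compound 2 `CCCCNCC(=O)Nc1cccc2c1CN(C)CC2c1ccccc1` gives 32 mg/kg, two values within the scatter of each other. Compound 3 `CCNCCC(=O)Nc1cccc2c1CN(C)CC2c1ccccc1`, not yet measured, has (ethylamino)methyl in place of butylamino on a saturated chain carbon bound to a carbonyl carbon. Going by the values given here, the one measured step that bears on this is a 1.3-fold lower number from compound 1 to compound 2 (0.10 log units; within the scatter), which also alters the group on the carbonyl side and stays small. No shift beyond the scatter is expected in this assay, the estimated step being a 1.1-fold higher number from compound 2 to compound 3 (0.04 log units; within the scatter). For compound 3 the expected value is 35 mg/kg, with an estimated range of 15 mg/kg to 80 mg/kg.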

Compound 3, dose for half-maximal effect: > 200 mg/kg
Compound 3 was reported as a limit; the forecaster's own chance of this, stated with the estimate: 10%; middle value at least 5.7-fold (0.75 log units) away from the limit.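

Compound 3 stands at a limit of this assay, not at a number: the limit of > 200 mg/kg in this assay, at which 1 of the 3 values shown sits.

The change of chain gives an at least 6.2-fold higher number from compound 2 to compound 3 (0.79 log units; beyond the scatter), and read against the urea-free butylamino start it gives an at least 5.0-fold higher number from compound 1 to compound 3 (0.69 log units; beyond the scatter). Compounds 1 and 2 lie within the scatter of each other, so only compound 3 shows that the chain on the carbonyl carbon is not freely variable.

Going by these compounds, compound 3 alters both the end group and the place of the amine at once, so which of these matters stays open. On these data alone, a 2-(butylamino)ethyl chain would separate the two, and the true size of both steps remains unknown behind the limit.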